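Dropping one fluoro from compound 3

This account rests on a few compounds, and the source may have more. Where it says the series, first, only, none or still open, it means among the compounds named here.

Compound 3 `COc1cc2c(Oc3ccc(NC(=O)NN4C(=O)CSC4c4ccc(F)c(F)c4)cc3)ccnc2cc1OC1CCN(C(=O)NC(C)C)CC1` gives 1060 nM in a functional assay on HT-29 cells (Homo sapiens) for inhibition, read by MTT assay (a higher number here means a weaker inhibitor, a lower number a stronger inhibitor), the lowest of the three numbers seen. Compound 1 `CCCCNC(=O)N1CCC(Oc2cc3nccc(Oc4ccc(NC(=O)NN5C(=O)CSC5c5ccc(F)cc5)cc4)c3cc2OC)CC1` gives 1700 nM, within the scatter of compound 3, while compound 2 `COc1cc2c(Oc3ccc(NC(=O)NN4C(=O)CSC4c4ccc(F)cc4)cc3)ccnc2cc1OC1CCN(C(=O)NC2CCCCC2)CC1` gives 3420 nM, beyond it. Going by the values given here, the single measured step, a 2.0-fold higher number from compound 1 to compound 2 (0.30 log units; within the scatter), concerns a cyclohexyl in place of butyl on an amide-type nitrogen and does not touch the fluorinated ring. Compound 4 `COc1cc2c(Oc3ccc(NC(=O)NN4C(=O)CSC4c4cccc(F)c4)cc3)ccnc2cc1OC1CCN(C(=O)NC(C)C)CC1` differs from compound 3 by hydrogen in place of fluoro on an aromatic carbon, that is 3,4-difluorophenyl to 3-fluorophenyl. Among the compounds with values here, no measured step bears on this change. For compound 4 the expected step is therefore a 1.2-fold higher number from compound 3 to compound 4 (0.09 log units; within the scatter), none beyond the scatter. Compound 4 is estimated at 1300 nM in this assay, with a range from 500 nM to 3500 nM.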

Compound 4, half-maximal inhibitory concentration: 670 nM
Estimate against measurement, compound 4: 1.9-fold (0.29 log units) above; measured number inside the range.
By their numbers in this assay, from the lowest: compounds 4, 3, 1 and 2 (each within the scatter of the next, the first and the last beyond it).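

In this assay, going by these compounds alone, the change from 3,4-difluorophenyl to 3-fluorophenyl gives the first reading on the fluorinated ring, a 1.6-fold lower number from compound 3 to compound 4 (0.20 log units; within the scatter), with the rest of the molecule unchanged. Hydrogen in place of fluoro on this aromatic carbon, ortho to a fluoro group and para to a large group, therefore leaves the number within the scatter, so this fluoro is not needed to hold activity here. Nothing available accounts for this result. The compounds shown leave open whether chloro or methyl on this carbon would read differently, and whether the remaining fluoro could also give way to hydrogen.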